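Series notes: chloroacetamide benzamides, chain tail swap

A few compounds are considered here, and "the series" means these few. Any claim that something is new, unique, unknown or untested is made for them only; others in the source may bear on it.

In an assay for inhibition of Nicotinamide N-methyltransferase (Homo sapiens), read by LC-MS, with stated times of 1 h and 30 min (a lower number here means a stronger inhibitor, a higher number a weaker inhibitor), compound 1 `CC(C)CCc1c(NC(=O)CCl)cc(C(=O)Nc2cccnc2Cl)cc1C(F)(F)F` gives 200 nM. Compound 2 `CC(C)CCN(C(=O)CCl)c1cc(C(=O)NCc2cccc([N+](=O)[O-])c2)cc(C(F)(F)F)c1` gives 180 nM in this assay. Compound 1 holds the higher of the two numbers, but the gap to compound 2 lies within the scatter, so the two stand together on the numbers shown. Among the compounds with values here, no step between measured compounds differing in one place has been seen, so nothing measured shows how a change on the saturated chain moves the read-out.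

Compound 3 `O=C(CCl)Nc1cc(C(=O)Nc2cccnc2Cl)cc(C(F)(F)F)c1CCc1ccccc1` has not yet been measured. It differs from compound 1 in one place: phenyl in place of isopropyl on a saturated chain carbon, two bonds along the chain from an aromatic carbon. Within the data shown here, with no measured precedent for such a tail swap, the step is expected to be small, in either direction or none beyond the scatter, and for compound 3 the expected step of no change at the digits printed from compound 1 to compound 3 (within the scatter) reflects that. Compound 3 is estimated at 200 nM, with a range from 60 nM to 650 nM.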

Compound 3, half-maximal inhibitory concentration: 17000 nM
Compound 3: middle estimate off by 85-fold (1.93 log units), on the low side; the measured number lies above the stated range.
By their numbers in this assay, from the lowest: compounds 2 and 1 (each within the scatter of the next); then compound 3.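

The saturated chain of compound 1 is not a neutral place for change: in this assay, phenyl in place of isopropyl on a saturated chain carbon, two bonds along the chain from an aromatic carbon, gives an 85-fold higher number from compound 1 to compound 3 (1.93 log units; beyond the scatter). Within the data shown here, this is the first measured step, and it shows that the read-out responds strongly to the end of this chain, with isopentyl to phenethyl moving towards a weaker inhibitor. Nothing measured bears on why the swap has this effect.

Still open, as far as these compounds go, is whether the phenyl ring itself carries the step or whether a cyclohexyl ring or a longer chain such as n-hexyl at the same place would bring a similar rise. From the compounds shown here alone, it also remains open whether the same tail swap would move compound 2 in the same direction.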